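Fluoro to methoxy exchange across two cores in paw edema

This account rests on a few compounds, and the source may have more. Where it says the series, first, only, none or still open, it means among the compounds named here.

Measured compounds:
compound 1 `Cc1ccc(-c2nn(-c3ccc(S(N)(=O)=O)cc3)cc2C(CC(=O)c2ccc(Cl)cc2)C(=O)c2ccc(F)cc2)cc1`, giving 53.5%
compound 2 `COc1ccc(C(=O)C(CC(=O)c2ccc(Cl)cc2)c2cn(-c3ccc(S(N)(=O)=O)cc3)nc2-c2ccc(C)cc2)cc1`, giving 53.8%
compound 3 `Cc1ccc(-c2nn(-c3ccc(S(N)(=O)=O)cc3)cc2-c2cc(-c3ccc(Cl)cc3)[nH]c2-c2ccc(F)cc2)cc1`, giving 75.4%

All three were tested in a functional assay on the whole organism (strain Wistar albino) for inhibition, with Rattus norvegicus as the target, read by paw edema, with stated times of 1 h and 2 h, at a dose of 0.32 mmol/kg by the intraperitoneal route; on this read-out lower numbers stand for less inhibition and higher numbers for more inhibition at the one dose given (going by the name of the read-out). Compound 1 and compound 2 share one core and differ only by methoxy in place of fluoro on an aromatic carbon. That change gave a number 0.3 percentage points higher from compound 1 to compound 2 (within the scatter), so the two numbers cannot be told apart. Compound 3 has a different core; the difference between the two cores is not broken down here. In this assay compound 3 gives 75.4%, the highest of the three numbers, and its steps to compound 1 and to compound 2 lie beyond the scatter.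

Compound 4 `COc1ccc(-c2[nH]c(-c3ccc(Cl)cc3)cc2-c2cn(-c3ccc(S(N)(=O)=O)cc3)nc2-c2ccc(C)cc2)cc1` has not yet been measured. It stands to compound 3 as compound 2 stands to compound 1: methoxy in place of fluoro on an aromatic carbon. The place line is the same, so this is the same change as before. Because the earlier step was a number 0.3 percentage points higher from compound 1 to compound 2 (within the scatter), the expectation is that compound 4 keeps close to compound 3, with an estimated step of a number 0.4 percentage points lower from compound 3 to compound 4 (within the scatter). For compound 4 the expected value in this assay is 75%, with the likely range from 65% to 85%.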

Compound 4, a percentage reported as inhibition, in the whole organism at one dose (the size of the read-out at that dose, not a potency): 49.7%
Compound 4: the middle estimate sits 25.3 percentage points above what was measured; the measured number lies below the stated range.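

Methoxy in place of fluoro on an aromatic carbon gave a number 25.7 percentage points lower from compound 3 to compound 4 (beyond the scatter), so on the core of compound 3 the change costs much of the inhibition seen in this assay. The neutral result on the core of compound 1 therefore did not carry over to the second core, and the two steps differ: the same change on two cores in this assay, a number 0.3 percentage points higher (within the scatter) from compound 1 to compound 2 and a number 25.7 percentage points lower (beyond the scatter) from compound 3 to compound 4, 26 percentage points apart, beyond the scatter of two such steps This shows that the outcome of 4-fluorophenyl to 4-methoxyphenyl depends on the core in these two pairs, but it does not show why, and two pairs at one dose give no rule for any further core.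

The compounds shown hold only fluoro and methoxy at this place, so it stays open whether the loss on the core of compound 3 is particular to methoxy or extends to other groups. An amine, a hydroxyl or a longer ether such as ethoxy at the same place on both cores would test how far the difference between the cores reaches.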